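A few compounds are considered here, and "the series" means these few. Any claim that something is new, unique, unknown or untested is made for them only; others in the source may bear on it.

Compound 1, `COc1cccc2cc(C(=O)NCCO)c(=N)oc12`, is the reference point here. In an assay on HeLa cells for displacement of a labelled ligand from adenosine receptor A3 (Homo sapiens), read by scintillation counting, with a stated time of 180 min, tested at 10 uM (a lower number here means less inhibition, a higher number more inhibition at the concentration tested (going by the name of the read-out)), compound 1 gives 23%, the highest of the three numbers in hand. Compound 2, `O=C(NCCCO)c1cc2ccccc2oc1=O`, gives 6% in this assay, and compound 3, `N=c1oc2ccc(Br)cc2cc1C(=O)NC1CCCC1`, gives 0%; the gap from compound 1 to each of them lies beyond the usual scatter of repeated measurements, with compound 2 the nearer and compound 3 the further away. Neither compound 2 nor compound 3 differs from compound 1 in only one place, so no single step can be read off between them. Compound 4, `COc1cccc2cc(C(=O)NCCCCCO)c(=N)oc12`, has not yet been measured. It differs from compound 1 in one spot: 3-hydroxypropyl in place of hydroxy on a saturated chain carbon, two bonds along the chain from an amide-type nitrogen. The shared core and the amide are kept; only the chain that carries the hydroxy group grows longer. Among the compounds with values here, no measured pair shows what such lengthening does in this assay, so the expectation rests on compound 1 alone. The step of a number 3 percentage points lower from compound 1 to compound 4 (within the scatter) is expected to be small, with no clear direction. Compound 4 is therefore estimated at 20%, within a range from 3% to 40%.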

Compound 4, a percentage reported as inhibition, at one concentration (the size of the read-out at that concentration, not a potency): 13%
The estimate for compound 4 lay 7 percentage points above the measured number; low and high end bracket the measured number.
By their numbers in this assay, from the lowest: compounds 3, 2, 4 and 1 (each within the scatter of the next, the first and the last beyond it).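

In this assay, 3-hydroxypropyl in place of hydroxy on a saturated chain carbon, two bonds along the chain from an amide-type nitrogen, gives a number 10 percentage points lower from compound 1 to compound 4 (within the scatter). Within the data shown here, this is the first pair here that differs in one place, so it gives the first direct reading at this position: the chain carrying the hydroxy group can grow by this much without a step beyond the usual scatter of the measurement. Nothing shown here bears on why the step has this size.

Still open, going by these compounds, is whether a chain ending in an amine or a carboxylic acid would read differently from these chains ending in hydroxy. Also open, on these data alone, is whether a still longer chain on the same core would give a step beyond the scatter.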